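Aryl ketone enlargement at the carbonyl carbon in compound 4

The compounds below may be only part of what the source reports. "The series", "measured", "known", "first", "only" and "open" are said of these compounds alone.

Compound 3 `CCOC(=O)N1CCN(CCCOc2ccc(C(C)=O)cc2)CC1` gives 39800 nM in an assay on isolated protein for binding affinity to histamine H2 receptor (Homo sapiens) (on this read-out higher numbers stand for weaker inhibition and lower numbers for stronger inhibition), the highest number of the three measured compounds: compound 2 `CCCCCC(=O)c1ccc(OCCCN2CCN(C(=O)C3CCC3)CC2)cc1` gives 10200 nM, and compound 1 `CCCCCC(=O)c1ccc(OCCCN2CCN(C(=O)OCC(C)C)CC2)cc1` gives 3720 nM. Both gaps from compound 3 are beyond the scatter, so compound 3 is the weakest binder here.

Compound 4 `CCOC(=O)N1CCN(CCCOc2ccc(C(=O)/C=C/c3ccc(OC)cc3)cc2)CC1` differs from compound 3 in one place: 2-(4-methoxyphenyl)ethenyl in place of methyl on a carbonyl carbon.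

Among the measured compounds shown here, the only measured single-site step, a 2.7-fold higher number from compound 1 to compound 2 (0.44 log units; beyond the scatter), concerns the carbonyl on the piperazine, not the aryl ketone, so it bears on the present change only as a sign that this series can shift modestly with a carbonyl substituent. Compound 1 and compound 3 differ in two places, one of them at the ketone carbonyl carbon; compound 1 gives 3720 nM and compound 3 gives 39800 nM, the lower number going with a longer group at that carbon, but the second difference prevents any clean reading.

For the measured compounds named here, no measured step isolates the ketone substituent. The expectation is a decrease in the number, a 5.0-fold lower number from compound 3 to compound 4 (0.70 log units; beyond the scatter), with wide uncertainty because the comparison between compound 1 3720 nM and compound 3 is confounded. Compound 4 is estimated at 8000 nM, within 1500 nM to 40000 nM.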

Compound 4, inhibition constant: 6760 nM
For compound 4 the middle estimate is 1.2-fold (0.07 log units) above the measured one; low and high end bracket the measured number.
By their numbers in this assay, from the lowest: compounds 1, 4 and 2 (each within the scatter of the next, the first and the last beyond it); then compound 3.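

In this assay, the carbonyl carbon of the aryl ketone now has a single-site step of its own: a 5.9-fold lower number from compound 3 to compound 4 (0.77 log units; beyond the scatter), with 2-(4-methoxyphenyl)ethenyl in place of methyl. The earlier link to this position ran only through compound 1 and compound 3, which differ in two places; here the change at this carbon alone lowers the number beyond the scatter, so an entering group with a six-membered aromatic ring and a double bond outside it is accepted there without a rise in the number. Nothing available accounts for the size or direction of this step.

The compounds shown leave open which part of the entering group goes with the lower number, since the double bond, the aromatic ring and the methoxy all arrive together, and chain length changes with them. A saturated 2-(4-methoxyphenyl)ethyl group, a plain styryl group without the methoxy, or a phenyl group directly on the same carbonyl carbon would pull these parts apart.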